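The source may hold more compounds than are shown below. What is called first, only, known or untested is meant among the compounds shown, and "the series" means these compounds.

Measured compounds:
In a functional assay on the whole organism (Tail, strain ICR) with Mus musculus as the target, in the tail flick test, with a stated time of 60 min, at a dose of 25 umol/kg by the oral route (on this read-out lower numbers stand for a weaker effect and higher numbers for a stronger effect at the one dose given), compound 1 `N=C(N)NCCC[C@H](NC(=O)CN(c1ncnc2c1ncn2C1CCCCO1)C1CC1)C(=O)OCc1ccccc1` gives 52.4%.
In this assay compound 2 `CSCC[C@H](NC(=O)CN(c1nc(Cl)nc2[nH]cnc12)C1CC1)C(=O)OCc1ccccc1` gives 30.8%.
In this assay compound 3 `C[C@H](NC(=O)CN(c1nc(Cl)nc2[nH]cnc12)C1CC1)C(=O)O` gives 44.6%.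

Compound 1 has the highest of these three numbers. Compound 3 comes nearest, and its number lies within the usual scatter, so the two cannot be told apart; compound 2 lies furthest, beyond the scatter. Compound 4 `CC(C)[C@H](NC(=O)CN(c1ncnc2c1ncn2C1CCCCO1)C1CC1)C(=O)OCc1ccccc1`, not yet measured, differs from compound 1 in one place: a group of 3 heavy atoms (3 carbon; no ring) in place of a group of 7 heavy atoms (4 carbon, 3 nitrogen; no ring), on a saturated chain carbon bound to an amide-type nitrogen and a carbonyl carbon. Among the compounds with values here, no measured pair differs in only this way, so no measured step guides the expectation. The group that leaves carries hydrogen-bond donors and an acceptor; the entering isopropyl carries none. With so little to go on, a modest downward step is expected in this assay, of roughly the size of the scatter. Compound 4 is therefore estimated at 42%, between 24% and 60%, meaning an expected step of a number 10.4 percentage points lower from compound 1 to compound 4 (beyond the scatter).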

Compound 4, a percentage reported as activity, at one dose (the size of the read-out at that dose, not a potency): 34.9%
Compound 4: the middle estimate sits 7.1 percentage points above what was measured; low and high end bracket the measured number.
By their numbers in this assay, from the lowest: compounds 2, 4, 3 and 1 (each within the scatter of the next, the first and the last beyond it).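

In this assay, placing isopropyl on the saturated chain carbon bound to an amide-type nitrogen and a carbonyl carbon gives a number 17.5 percentage points lower from compound 1 to compound 4 (beyond the scatter) and shows that the oral effect depends on the group held at this position. This single change removes heavy atoms and hydrogen-bond donors together, so the step cannot show which of them matters. No measurement here explains the step. The compounds shown leave open how a simple amine, a carboxylic acid or a longer carbon chain would behave at this position. They also leave open whether the same step would appear on another core.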